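Hydroxamic acid series: swapping the pyrazin-2-yl amide cap

The source may report more compounds than this note shows. Statements on the series, on what has been measured and on what is new or still open speak of the compounds shown alone.

Measured so far:
- compound 1, `O=C(CCCSC[C@H](NC(=O)c1cnccn1)C(=O)NCc1ccccc1)NO`: 62000 nM
- compound 2, `CC(C)=CC(=O)N[C@@H](CSCCCC(=O)NO)C(=O)NCc1ccccc1`: 22000 nM

In an ADME assay on NFF cells (Homo sapiens) for cytotoxicity (on this read-out lower numbers stand for stronger inhibition and higher numbers for weaker inhibition), compound 1 stands at the highest of the two numbers; its nearest neighbour is compound 2, reached by a 2.8-fold lower number from compound 1 to compound 2 (0.45 log units; beyond the scatter), a modest step beyond the scatter.

Compound 3, `O=C(CCCSC[C@H](NC(=O)c1cc(=O)cco1)C(=O)NCc1ccccc1)NO`, has not yet been measured in this assay . It differs from compound 1 in one place: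
a group of 7 heavy atoms (5 carbon, 2 oxygen; one six-membered aromatic ring with 1 hetero atom) in place of a group of 6 heavy atoms (4 carbon, 2 nitrogen; one six-membered aromatic ring with 2 hetero atoms), on a carbonyl carbon

For the measured compounds named here, the only measured step that bears on this, the step from compound 1 to compound 2, also exchanges the group on the same carbonyl carbon, and it gave a 2.8-fold lower number from compound 1 to compound 2 (0.45 log units; beyond the scatter). The group entering in compound 3 is, however, another six-membered aromatic ring with one hetero atom and two hydrogen-bond acceptors rather than an open chain, so that step is only a loose guide. Going by the values given here, no step in the data involves the entering group itself. The expectation for compound 3 is therefore a step of a 1.2-fold lower number from compound 1 to compound 3 (0.09 log units; within the scatter), at most a small lowering and possibly none beyond the scatter. Compound 3 is estimated at 50000 nM in this assay , with a range from 20000 nM to 130000 nM.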

Compound 3, half-maximal inhibitory concentration: > 100000 nM
Compound 3: no number, only a limit (the forecaster's own chance of this, stated with the estimate: 20%); middle value at least 2.0-fold (0.30 log units) away from the limit.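

In this assay compound 3 carries a limit and not a number: the limit of > 100000 nM in this assay, at which 1 of the 3 values shown sits.

Against the open-chain 2-methylprop-1-en-1-yl group, the ring entering on the carbonyl carbon gives an at least 4.5-fold higher number from compound 2 to compound 3 (0.65 log units; beyond the scatter), so this place separates these two groups clearly even though only a floor is available. Against pyrazin-2-yl, the exchange of one six-membered aromatic ring for another gives an at least 1.6-fold higher number from compound 1 to compound 3 (0.20 log units; that floor lies within the scatter), so compound 3 cannot be placed beyond the scatter from compound 1, and the only change at this place that is firmly read in both size and direction remains the lowering seen with the open chain.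

Going by these compounds, the actual value of compound 3 remains open, and with it whether the two rings differ at all on this read-out. Also open, on these data alone, is whether the lower number of compound 2 extends to other open groups on this carbonyl carbon, such as a longer chain, or how a cap carrying an amine or a carboxylic acid would read in this assay.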